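Catechol chalcones: methyl for hydroxy on the ketone ring

The compounds below may be only part of what the source reports. "The series", "measured", "known", "first", "only" and "open" are said of these compounds alone.

In an assay on RBL-1 cells for inhibition of Polyunsaturated fatty acid 5-lipoxygenase (Rattus norvegicus) (on this read-out higher numbers stand for weaker inhibition and lower numbers for stronger inhibition), compound 1 `O=C(/C=C/c1ccc(O)c(O)c1)c1cccc(O)c1` gives 4.2 nM, the lowest of the two numbers recorded so far. Among the compounds with values here, the only other measured member, compound 2 `O=C(/C=C/c1ccc(O)c(O)c1)c1ccc([N+](=O)[O-])cc1`, carries a nitro group on the ketone-bearing ring, and in this assay compound 2 gives 23 nM; the gap between compound 1 and compound 2 lies beyond the usual scatter. Compound 3 `Cc1cccc(C(=O)/C=C/c2ccc(O)c(O)c2)c1` is the next member to be measured: methyl in place of hydroxy on an aromatic carbon, so one hydrogen-bond donor and one acceptor leave the ketone-bearing ring. Within the data shown here, no measured pair isolates this change, and the nitro case of compound 2 is a different substitution at a different place, so it offers only a loose hint that altering this ring costs some potency. A modest loss, likely beyond the scatter, is expected. Compound 3 is estimated at 12 nM in this assay, within a range of 4 nM to 40 nM. The expected step of a 2.9-fold higher number from compound 1 to compound 3 (0.46 log units; beyond the scatter) is a moderate weakening.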

Compound 3, half-maximal inhibitory concentration: 27 nM
For compound 3 the middle estimate is 2.3-fold (0.35 log units) below the measured one, and the stated range covers the measured number.
By their numbers in this assay, from the lowest: compound 1; then compounds 2 and 3 (each within the scatter of the next).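

In this assay, within the data shown here, compounds 1 and 3 form the only pair that isolates a change on the ketone-bearing ring: methyl in place of hydroxy, meta to a large group, gives a 6.4-fold higher number from compound 1 to compound 3 (0.81 log units; beyond the scatter). Among these compounds, the step lies beyond the scatter, so this position is not indifferent to the change, which the earlier compounds could not show. No available data explain the direction or size of the step.

From the compounds shown here alone, it remains open whether any replacement of hydroxy at this place gives a similar step or whether this result is specific to methyl; a methoxy group, an amine or a fluorine atom there would test this. The compounds shown also leave open whether the same change gives a similar step elsewhere on this ring.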